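Trifluoromethyl in place of cyano: working notes

A few compounds are considered here, and "the series" means these few. Any claim that something is new, unique, unknown or untested is made for them only; others in the source may bear on it.

Measured in a functional assay on HepG2 cells (Homo sapiens) for inhibition, read by MTT assay; on this read-out higher numbers stand for weaker inhibition of growth and lower numbers for stronger inhibition of growth:
compound 1 `COc1cc2oc(-c3cccc(NC(=O)c4ccc(Br)cc4)c3)cc(=O)c2c(OC)c1OC`: 8850 nM
compound 2 `COc1cc2oc(-c3cccc(NC(=O)c4ccccc4Br)c3)cc(=O)c2c(OC)c1OC`: 23100 nM
compound 3 `COc1cc2oc(-c3cccc(NC(=O)c4ccc(C#N)cc4)c3)cc(=O)c2c(OC)c1OC`: 10200 nM

On these numbers, compound 3 cannot be separated from compound 1, and the clear gap is a 2.3-fold lower number from compound 2 to compound 3 (0.36 log units; beyond the scatter). Compound 4 `COc1cc2oc(-c3cccc(NC(=O)c4ccc(C(F)(F)F)cc4)c3)cc(=O)c2c(OC)c1OC` carries trifluoromethyl in place of cyano on an aromatic carbon, para to a large group: trifluoromethyl in place of cyano on an aromatic carbon. Within the data shown here, the nearest precedent is the exchange of bromo for cyano on an aromatic carbon, a 1.2-fold higher number from compound 1 to compound 3 (0.06 log units; within the scatter), which stays within the scatter. The step of a 2.6-fold higher number from compound 1 to compound 2 (0.42 log units; beyond the scatter) comes with a change of place of the bromo group, and compound 4 has no such change. No shift beyond the scatter is therefore expected in this assay, the expected change being a 1.0-fold lower number from compound 3 to compound 4 (0.01 log units; within the scatter). Compound 4 is estimated at 10000 nM, with an expected range of 5500 nM to 18000 nM.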

Compound 4, concentration for 50% growth inhibition: 61100 nM
Estimate against measurement, compound 4: 6.1-fold (0.79 log units) below, and the stated range ends below it.
By their numbers in this assay, from the lowest: compounds 1 and 3 (each within the scatter of the next); then compound 2; then compound 4.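

In this assay the place para to a large group proves sensitive to its substituent: a 6.0-fold higher number from compound 3 to compound 4 (0.78 log units; beyond the scatter) and a 6.9-fold higher number from compound 1 to compound 4 (0.84 log units; beyond the scatter) come with trifluoromethyl, although bromo and cyano could not be separated there. With a 2.6-fold higher number from compound 2 to compound 4 (0.42 log units; beyond the scatter) as well, an exchange at an unchanged place can outweigh moving the bromo group. Nothing at hand gives a reason for these steps.

Going by these compounds, whether an amine or a carboxylic acid at this place would stay close to compound 1 and compound 3 or move towards compound 4 remains open. Also open, on these data alone, is whether methyl would follow trifluoromethyl.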